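Long Alkyl Chain Replaces the Dimethylamino Group

The compounds below may be only part of what the source reports. "The series", "measured", "known", "first", "only" and "open" are said of these compounds alone.

Compound 1 `Nc1nc(O)c2c(n1)n(C1OC(CO)[C@@H](O)[C@H]1O)c(=O)n2Cc1ccc(Cl)c(Cl)c1` gives 0% in a functional assay on the whole organism with Mus musculus as the target (a higher number here means a larger maximal response, a lower number a smaller maximal response), and compound 2 `CN(C)CCCn1c(=O)n(C2OC(CO)[C@@H](O)[C@H]2O)c2nc(N)nc(O)c21` gives 63% in this assay; the step of a number 63 percentage points higher from compound 1 to compound 2 (beyond the scatter) leaves compound 2 with the highest of the two numbers. Compound 3 `CCCCCCCCCCn1c(=O)n(C2OC(CO)[C@@H](O)[C@H]2O)c2nc(N)nc(O)c21` differs from compound 2 by heptyl in place of dimethylamino on a saturated chain carbon, three bonds along the chain from an aromatic nitrogen. Within the data shown here, only the one measured step, which was large, bears on this change, and it concerns a different group, so guidance is limited. An expected moderate loss, a number 23 percentage points lower from compound 2 to compound 3 (beyond the scatter), is estimated for compound 3, giving 40% with a range from 10% to 75%.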

Compound 3, largest response reached (reported as maximal response), in percent of the reference or control that the assay uses: 0%
For compound 3 the middle estimate is 40 percentage points above the measured one; the measured number lies below the stated range.
By their numbers in this assay, from the lowest: compounds 1 and 3 (each within the scatter of the next); then compound 2.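

In this assay, heptyl in place of dimethylamino means a number 63 percentage points lower from compound 2 to compound 3 (beyond the scatter), so on this chain a purely carbon group does not keep the response seen with dimethylamino. Nonyl in place of 3,4-dichlorophenyl gives no change at the digits printed from compound 1 to compound 3 (within the scatter), which leaves compound 2 as the only one of the three with a response. Nothing available explains this loss. The compounds shown leave open whether the response depends on dimethylamino specifically or on any amine. A primary amine or a carboxylic acid in place of dimethylamino would help to separate these possibilities.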